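Butoxy in Place of Fluoro: Expected Cytotoxicity

This account rests on a few compounds, and the source may have more. Where it says the series, first, only, none or still open, it means among the compounds named here.

Of the compounds shown here, three sharing a core have been tested in a toxicity assay on MRC5 cells (Homo sapiens) for cytotoxicity, read by MTT assay, with a stated time of 72 h; a higher number here means that more compound is needed for the effect, a lower number that less compound is needed. Compound 1 `Cn1cc(/C=N/NC(N)=S)c2ccccc21` reached only the limit of the assay, giving > 200000 nM. Compound 3 `CN(C)c1ccc(/C=N/N=C(/N)S)c2ccccc12` likewise gave a limit, > 200000 nM. Compound 2 `NC(=S)N/N=C/c1ccc(F)c2ccccc12`, the starting point of the step followed here, also sits at the limit of this assay, with > 200000 nM. Going by the values given here, no number is known for compound 2, only this limit, and the same holds for the two other compounds; the limit of > 200000 nM in this assay, at which 3 of the 3 values shown sit, is all the numbers show, so no step between measured compounds can be sized.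

Compound 4 `CCCCOc1ccc(/C=N/NC(N)=S)c2ccccc12` is not yet measured. It differs from compound 2 by butoxy in place of fluoro on an aromatic carbon. Among the compounds with values here, every measured value rests at the limit, and no measured step exists with which the change from fluoro to butoxy could be compared, so no direction can be read from the data. The expectation for compound 4 is that it remains at or near the limit of this assay. The expected step is a number no higher from compound 2 to compound 4 (the limit leaves the size open), that is, none beyond the scatter. The estimate for compound 4 in this assay is 200000 nM, with a range from 100000 nM to 400000 nM, most likely reported again only as a limit.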

Compound 4, half-maximal effective concentration: 41000 nM
Compound 4: middle estimate off by 4.9-fold (0.69 log units), on the high side; the whole stated range lies above it.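

In this assay, butoxy in place of fluoro on an aromatic carbon gives an at least 4.8-fold lower number from compound 2 to compound 4 (0.68 log units; beyond the scatter). This shows that a change at this position, para to a group of 6 heavy atoms, can bring the read-out within the range of the assay, which none of the earlier compounds had shown. Because compound 2 has only a limit and no number, the true size of the step remains unknown and only its lower bound can be stated: the limit of > 200000 nM in this assay, at which 3 of the 4 values shown sit.

A single pair cannot separate the contribution of the butyl chain from that of the oxygen joining it to the aromatic carbon, and a methoxy, a hexyloxy or a plain butyl group at the same place would be needed to tell them apart. On these data alone, it also remains open whether an amine or a carboxylic acid here would bring the read-out within range, and whether the same butoxy group would have a comparable effect on the core of compound 1.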